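The source may hold more compounds than are shown below. What is called first, only, known or untested is meant among the compounds shown, and "the series" means these compounds.

Compound 3 `CCOC(=O)C1=C(C)NC(C)=C(C(=O)OCC)C1c1ccc(OCC(=O)NNC(=O)c2cccs2)cc1` stands highest of the three compounds measured in a functional assay on the whole organism (strain Wistar) for inhibition, with Rattus norvegicus as the target, read by paw edema, with stated times of 30 min and 0.5 h, at a dose of 20 mg/kg; a higher number here means more inhibition at the dose given (going by the name of the read-out), a lower number less inhibition: compound 3 gives 44%, while compound 2 `CCOC(=O)C1=C(C)NC(C)=C(C(=O)OCC)C1c1ccc(OCC(=O)Nc2c(C)cccc2C)cc1` gives 15.9% and compound 1 `CCOC(=O)C1=C(C)NC(C)=C(C(=O)OCC)C1c1ccc(OCC(=O)NCc2ccccc2)cc1` gives 8.33%. Compound 4 `CCOC(=O)C1=C(C)NC(C)=C(C(=O)OCC)C1c1ccc(OCC(=O)NN2C(=O)c3ccccc3C2=O)cc1` differs from compound 3 at one place: a group of 11 heavy atoms (8 carbon, 1 nitrogen, 2 oxygen; one five-membered non-aromatic ring with 1 hetero atom, one six-membered aromatic ring of carbon only) in place of a group of 8 heavy atoms (5 carbon, 1 nitrogen, 1 oxygen, 1 sulfur; one five-membered aromatic ring with 1 hetero atom), on an amide-type nitrogen. Among the compounds with values here, the steps that bear on this change are the two that lead into compound 3, a number 35.7 percentage points higher from compound 1 to compound 3 (beyond the scatter) and a number 28.1 percentage points higher from compound 2 to compound 3 (beyond the scatter), both gains on replacing the group on the same amide-type nitrogen. Within the data shown here, no measured step swaps one such group for another whose entering part carries no hydrogen-bond donor, so the direction is uncertain. For compound 4 a downward step of modest size is expected, a number 14 percentage points lower from compound 3 to compound 4 (beyond the scatter). Compound 4 is therefore expected to give about 30%, within 12% to 48%.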

Compound 4, a percentage reported as inhibition, in the whole organism at one dose (the size of the read-out at that dose, not a potency): 34.1%
Estimate against measurement, compound 4: 4.1 percentage points below, and the stated range covers the measured number.
By their numbers in this assay, from the lowest: compounds 1 and 2 (each within the scatter of the next); then compounds 4 and 3 (each within the scatter of the next).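

On the amide-type nitrogen, a group with 0 hydrogen-bond donors and a second ring, non-aromatic, can replace ((thiophen-2-yl)carbonyl)amino in this assay with only a number 9.9 percentage points lower from compound 3 to compound 4 (within the scatter) as the result. The gains over the earlier groups persist, with a number 18.2 percentage points higher from compound 2 to compound 4 (beyond the scatter) and a number 25.8 percentage points higher from compound 1 to compound 4 (beyond the scatter), so among these compounds they do not need the thiophene ring. No measurement available here accounts for these steps. From the compounds shown here alone, compound 3 and compound 4 both place a second nitrogen on the amide-type nitrogen, so whether that nitrogen matters stays open. A simple acetylamino group or a free amino group there would test this.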